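Swapping Ring Oxygen for Sulfur Beside a Sulfonyl Group

The source may hold more compounds than are shown below. What is called first, only, known or untested is meant among the compounds shown, and "the series" means these compounds.

Measured so far:
compound 1, `Cc1ccc(-c2c[nH]nc2S(=O)(=O)CC2=NCCS2)cc1`: "not active" (no number reported)
compound 2, `COc1ccc(-c2noc(-c3ccc(C)cc3)c2S(=O)(=O)CC2=NCCO2)cc1`: 70%

Going by the values given here, in a functional assay, tested at 50 ug/mL (on this read-out lower numbers stand for a weaker effect and higher numbers for a stronger effect at the one concentration tested), compound 2 gives 70%, the only number in this set. Compound 1 was reported only as not active, and since the two structures differ in more than one place, nothing beyond these two results can be drawn from them. Compound 3 `COc1ccc(-c2noc(-c3ccc(C)cc3)c2S(=O)(=O)CC2=NCCS2)cc1` has not yet been measured. On these data alone, it differs from compound 2 in a single place: a group of 5 heavy atoms (3 carbon, 1 nitrogen, 1 sulfur; one five-membered non-aromatic ring with 2 hetero atoms) in place of a group of 5 heavy atoms (3 carbon, 1 nitrogen, 1 oxygen; one five-membered non-aromatic ring with 2 hetero atoms), on a saturated chain carbon bound to a sulfonyl sulfur Compound 1 carries the entering group on a different core and was not active, but no single-step comparison exists, so the size of this change in this assay is unknown. A modest weakening is expected, and the step of a number 15 percentage points lower from compound 2 to compound 3 (beyond the scatter) is estimated to sit near the edge of the usual scatter. Compound 3 is expected to give 55%, within a range from 25% to 80%.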

Compound 3, a percentage reported as activity, at one concentration (the size of the read-out at that concentration, not a potency): "not active" (no number reported)
Compound 3 has no reported number here; the estimate stays without a comparison.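

Going by these compounds alone, compound 3 is reported as "not active" (no number reported) and carries no number, so no step from compound 2 to compound 3 can be read. The compounds shown leave open how large the effect of exchanging ring oxygen for sulfur is, and no evidence bears on its cause.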